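The source may report more compounds than this note shows. Statements on the series, on what has been measured and on what is new or still open speak of the compounds shown alone.

Measured so far:
- compound 1, `CCCCCCCCc1ccc(OCC(=O)Cn2nnc(-c3ccccc3)n2)cc1`: 24 nM
- compound 2, `CCCCCCCCc1ccc(OCC(=O)Cn2nnnc2-c2cccs2)cc1`: 55 nM
- compound 3, `CCCCCCCCc1ccc(OC(C)C(=O)Cn2nnc(-c3ccccc3)n2)cc1`: 24 nM

In an assay on microsomes from brain for inhibition of Fatty-acid amide hydrolase 1 (Rattus norvegicus), read by fluorescence and HPLC, with a stated time of 60 min (on this read-out higher numbers stand for weaker inhibition and lower numbers for stronger inhibition), compound 3 stands level with compound 1 at the digits shown, and the two together give the lowest numbers of the three; compound 2 sits higher than compound 3 by a margin beyond the scatter. Among the compounds with values here, the step of no change at the digits printed from compound 1 to compound 3 (within the scatter) is the only change within the shared core that has been followed, and it leaves the read-out unchanged.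

Compound 4, `CC(Oc1ccc(Oc2ccc(F)cc2)cc1)C(=O)Cn1nnc(-c2ccccc2)n1`, differs from compound 3 by 4-fluorophenoxy in place of octyl on an aromatic carbon. Within the data shown here, no measured step touches this part of the molecule: the step from compound 1 to compound 3 concerns the chain carbon, and the difference between compound 1 and compound 2 concerns the heteroaryl end. The replacement of the octyl tail is therefore uncharted, and the expectation rests only on the other tail changes having been small. For compound 4 a step of a 2.1-fold higher number from compound 3 to compound 4 (0.32 log units; beyond the scatter) is expected, in the direction of a somewhat higher number, with wide uncertainty. Compound 4 is thus estimated at 50 nM in this assay, within the range 10 nM to 300 nM.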

Compound 4, half-maximal inhibitory concentration: 24 nM
Compound 4: the middle estimate sits 2.1-fold (0.32 log units) above what was measured; the range from low to high includes it.
By their numbers in this assay, from the lowest: compounds 1, 3 and 4 (each within the scatter of the next); then compound 2.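

In this assay, 4-fluorophenoxy in place of octyl on an aromatic carbon, para to a large group, gives no change at the digits printed from compound 3 to compound 4 (within the scatter). Within the data shown here, this is the first measured change at this position, and it shows that the octyl chain is not needed to hold the read-out at this level: compound 4 carries one six-membered aromatic ring of carbon only and a hydrogen-bond acceptor in the tail, and compound 3 has neither there. No supporting data bear on why the two tails read alike.

Open, as far as these compounds go, is whether a carboxylic acid, an amine or a shorter alkyl chain at this position would read level as well. Also open, from the compounds shown here alone, is whether 4-fluorophenoxy gives the same result without the added methyl of compound 3, or with the heteroaryl end of compound 2.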